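Swapping the aryl group on the triazole: compound 2 to 3

A few compounds are considered here, and "the series" means these few. Any claim that something is new, unique, unknown or untested is made for them only; others in the source may bear on it.

Compound 1 `Cc1cccc(-n2cc(-c3ccccc3NS(=O)(=O)c3c[nH]c(=O)[nH]c3=O)nn2)c1` — 3620 nM
Compound 2 `O=c1[nH]cc(S(=O)(=O)Nc2cccc(-c3cn(-c4ccccc4F)nn3)c2)c(=O)[nH]1` — 13900 nM

Of the compounds shown here, two have been measured in a functional assay on HepG2 cells (Homo sapiens) for antiproliferative activity, read by MTT assay, with a stated time of 24 h; on this read-out higher numbers stand for weaker inhibition and lower numbers for stronger inhibition. Compound 1 gives 3620 nM in this assay, and compound 2 gives 13900 nM. Compound 2 therefore holds the highest of the two numbers, and the gap to compound 1 lies beyond the scatter of repeated measurements, so compound 2 is the weaker of the pair. The two compounds differ in more than one place, so no single step can be read between them.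

The unmeasured compound 3 `O=c1[nH]cc(S(=O)(=O)Nc2cccc(-c3cn(-c4ccc(Cl)cc4)nn3)c2)c(=O)[nH]1` differs from compound 2 in exactly one place: 4-chlorophenyl in place of 2-fluorophenyl on an aromatic nitrogen. Within the data shown here, no measured pair shows what such a swap does here, so the direction of the step is open. The expected step from compound 2 to compound 3 is a 1.7-fold lower number from compound 2 to compound 3 (0.24 log units; within the scatter), which stays within the usual scatter. Compound 3 is expected to give about 8000 nM in this assay, with a range from 2500 nM to 25000 nM.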

Compound 3, half-maximal inhibitory concentration: 1960 nM
Estimate against measurement, compound 3: 4.1-fold (0.61 log units) above; the measured number lies below the stated range.
By their numbers in this assay, from the lowest: compounds 3 and 1 (each within the scatter of the next); then compound 2.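

In this assay, among these compounds, exchanging the aryl group on an aromatic nitrogen of the five-membered aromatic ring gives a 7.1-fold lower number from compound 2 to compound 3 (0.85 log units; beyond the scatter), the first step here that can be read at a single place, and it shows that the number responds to the aryl group at this position. The two groups match in their counts of heavy atoms, hydrogen-bond donors and hydrogen-bond acceptors, and neither carries a net charge, so a step beyond the scatter arises with no change in any of those counts. Nothing measured here accounts for the size or direction of this step.

This swap changes both the halogen and its place on the phenyl ring, so the compounds shown cannot separate the two, and a pair with 4-fluorophenyl or 2-chlorophenyl at this position would be needed to do so. Also open, on these data alone, is how this position responds to groups of other kinds, such as a phenyl ring carrying a methoxy group or a carboxylic acid, or a cyclohexyl group in place of the phenyl ring.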